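The source may report more compounds than this note shows. Statements on the series, on what has been measured and on what is new or still open speak of the compounds shown alone.

In a functional assay on HUVEC cells (Homo sapiens) for inhibition, read by ELISA and BrdU incorporation (a lower number here means a stronger inhibitor, a higher number a weaker inhibitor), three amides built on one core have been measured. Compound 1 `O=C(Nc1cccc2cccnc12)c1ccccc1` gives 1160 nM, compound 3 `Cc1cnc(O)c(C(=O)Nc2cccc3cccnc23)c1` gives 1150 nM, and compound 2 `O=C(Nc1cccc2cccnc12)c1cc(Br)cnc1O` gives 560 nM, the lowest number of the three. Still unmeasured is compound 4 `O=C(Nc1cccc2cccnc12)c1cncc(Br)c1`, which keeps the bromo group of compound 2 and differs from it thus: hydrogen in place of hydroxy on an aromatic carbon. That is hydrogen in place of hydroxy on an aromatic carbon.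

For the measured compounds named here, no measured step isolates this change. Going by the values given here, the one measured step, a 2.1-fold higher number from compound 2 to compound 3 (0.31 log units; beyond the scatter), puts methyl in place of bromo and leaves the hydroxy untouched, so it bears only indirectly, as a guide to the size of a single change. Compound 1 also lacks the hydroxy and stands at 1160 nM, although it differs from compound 2 in more than one place. A modest rise in this assay is therefore expected, not a large one. The estimate amounts to a 1.7-fold higher number from compound 2 to compound 4 (0.23 log units; within the scatter). For compound 4 the expected value is 950 nM, with an estimated range of 400 nM to 2200 nM.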

Compound 4, half-maximal inhibitory concentration: 346 nM
Estimate against measurement, compound 4: 2.7-fold (0.44 log units) above; the whole stated range lies above it.
By their numbers in this assay, from the lowest: compounds 4 and 2 (each within the scatter of the next); then compounds 3 and 1 (each within the scatter of the next).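

In this assay the change of hydroxy to hydrogen, on the aromatic carbon next to the ring nitrogen and para to a bromo group, gives a 1.6-fold lower number from compound 2 to compound 4 (0.21 log units; within the scatter), so with the bromo group kept, this hydroxy makes no difference beyond the scatter. For the compounds shown here, this is the first direct reading at this position, since the only earlier step, a 2.1-fold higher number from compound 2 to compound 3 (0.31 log units; beyond the scatter), left the hydroxy in place and changed the bromo group. Nothing on hand accounts for this result.

The compounds shown leave open whether an amine, a methoxy group or a fluoro group on this same carbon would shift the number, since hydrogen and hydroxy are the only two groups compared here. They also leave open whether methyl in place of bromo would give the same step once the hydroxy is gone.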